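Swapping Nitro for Chloro on a Weak Inhibitor

The source may hold more compounds than are shown below. What is called first, only, known or untested is meant among the compounds shown, and "the series" means these compounds.

Of the compounds shown here, three sharing one core have been tested in a functional assay on A549 cells (Homo sapiens) for inhibition, read by MTT assay, with a stated time of 24 h; a higher number here means a weaker inhibitor, a lower number a stronger inhibitor. Compound 1 `CCOC(=O)C1=Cc2ccccc2OC1(OCc1cn(-c2ccc(C)cc2)nn1)C(F)(F)F` gives 19700 nM in this assay. Compound 2 `O=C(O)C1=Cc2ccccc2OC1(OCc1cc(-c2ccc([N+](=O)[O-])cc2)no1)C(F)(F)F` reaches only the limit of this assay, > 150000 nM. Compound 3 `CCOC(=O)C1=Cc2ccccc2OC1(OCc1cc(-c2ccc([N+](=O)[O-])cc2)no1)C(F)(F)F` likewise sits at the limit, > 150000 nM. The step that the two limits leave unreadable from compound 2 to compound 3 therefore cannot be read, because of the limit of > 150000 nM in this assay, at which 2 of the 3 values shown sit. Within the data shown here, compound 1 differs from compound 3 in more than one place, so its value shows only that a different ring and substituent bring the inhibition down to a number that can be read.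

Compound 4 `CCOC(=O)C1=Cc2ccccc2OC1(OCc1cc(-c2ccc(Cl)cc2)no1)C(F)(F)F` has not yet been measured. It differs from compound 3 by chloro in place of nitro on an aromatic carbon. No measured step in this assay touches the group on this aromatic ring, and the one step that is shown, from compound 2 to compound 3, is unreadable. The direction of the change from compound 3 to compound 4 is therefore open on these numbers alone. Since compound 3 stands at the limit, compound 4 is expected to remain a weak inhibitor, with an estimated step of an at least 1.6-fold lower number from compound 3 to compound 4 (0.22 log units; that floor lies within the scatter). The estimate for compound 4 in this assay is 90000 nM, in the range from 25000 nM to 150000 nM, and it may again come back as a limit.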

Compound 4, half-maximal inhibitory concentration: 19100 nM
Compound 4: middle estimate off by 4.7-fold (0.67 log units), on the high side; measured number outside the range, below it.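

In this assay, the change from 4-nitrophenyl to 4-chlorophenyl gives an at least 7.8-fold lower number from compound 3 to compound 4 (0.89 log units; beyond the scatter), with the rest of the structure untouched. This is the first sign that the group at this place on the aromatic ring, para to a large group, can move the measured inhibition by more than the usual scatter, and it is the only step among these compounds whose size can be read at all. The true step may be larger still, because compound 3 provides only a limit and not a number: the limit of > 150000 nM in this assay, at which 2 of the 4 values shown sit.

The step from compound 2 to compound 3 still cannot be read, so the compounds shown say nothing about how the ethyl group on that oxygen affects inhibition, whether on the 4-nitrophenyl series or on the 4-chlorophenyl one. Also open, going by these compounds, is whether a fluoro, a methoxy or an amine at this same place on the ring would push the number lower than chloro does, or would return it to the limit.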